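Oxadiazole sulfonamides: benzyl swap at the far ring

The compounds below may be only part of what the source reports. "The series", "measured", "known", "first", "only" and "open" are said of these compounds alone.

Working notes on a small set of sulfonamide-bearing prostaglandin EP1 ligands. Compound 1 `CCc1ccccc1N(CC(=O)OCc1ccc(OC)cc1)S(=O)(=O)c1ccc(C)cc1` carries an ester arm; in an assay on CHO cells for displacement of a labelled ligand from prostaglandin E2 receptor EP1 subtype (Homo sapiens) (on this read-out lower numbers stand for stronger inhibition and higher numbers for weaker inhibition), compound 1 gives 63 nM; 63.1 nM (2 entries), two entries that agree with each other (the several entries of compound 1 in this assay, 63 nM; 63.1 nM (2 entries)). Compound 2 `CCOc1ccc(Cc2nnc(CN(c3ccccc3CC)S(=O)(=O)c3ccc(C)cc3)o2)cc1` moves to the oxadiazole-linked benzyl type, and in this assay compound 2 gives 126 nM. Compound 3 `Cc1ccc(S(=O)(=O)N(Cc2nnc(Cc3ccc(C(F)(F)F)cc3)o2)c2cccc(Cl)c2C)cc1` keeps that oxadiazole frame with a chloro-methyl-substituted aniline and a 4-(trifluoromethyl)benzyl group, and in this assay compound 3 gives 50.1 nM. Among the single numbers shown, compound 3 sits below compound 2 by a margin beyond the usual scatter, while the two entries of compound 1 lie within the scatter of compound 3, so no order between compound 1 and compound 3 is claimed.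

Compound 4 `Cc1ccc(S(=O)(=O)N(Cc2nnc(Cc3ccc(Cl)cc3Cl)o2)c2cccc(Cl)c2C)cc1` is not yet measured. It differs from compound 3 in one place: 2,4-dichlorophenyl in place of 4-(trifluoromethyl)phenyl on a saturated chain carbon bound to an aromatic carbon. Going by the values given here, no measured pair in the set isolates a change of this kind, so there is no step to lean on. The expectation is a change of no more than the scatter in either direction; the step from compound 3 to compound 4 is estimated at a 1.2-fold higher number from compound 3 to compound 4 (0.08 log units; within the scatter). In this assay compound 4 is therefore expected near 60 nM, with a plausible range from 20 nM to 200 nM.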

Compound 4, half-maximal inhibitory concentration: 63.1 nM
Compound 4: the middle estimate sits 1.1-fold (0.02 log units) below what was measured; measured number inside the range.
By their numbers in this assay, from the lowest: compounds 3, 4 and 2 (each within the scatter of the next, the first and the last beyond it).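

On a saturated chain carbon bound to an aromatic carbon, 2,4-dichlorophenyl in place of 4-(trifluoromethyl)phenyl gives a 1.3-fold higher number from compound 3 to compound 4 (0.10 log units; within the scatter) in this assay. Going by these compounds alone, this is the first pair in the set that differs in one place, and it shows that two differently substituted phenyl groups at this place on the shared core cannot be told apart on this read-out, something the earlier compounds, with no such pair among them, could not show. Nothing measured in the set speaks to why these two phenyl groups read alike.

Still open, going by these compounds, is how the read-out responds when the phenyl group at this place carries a carboxylic acid or an amine, or when a longer chain stands in place of the single saturated carbon that holds the ring. Also open, on these data alone, is whether the same swap gives a similar step on a core with a different group on the sulfonamide nitrogen, such as the ethylphenyl group of compound 2.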